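Dimethoxyphenyl enone series: chalcones on a pyrazole core

A few compounds are considered here, and "the series" means these few. Any claim that something is new, unique, unknown or untested is made for them only; others in the source may bear on it.

Measured so far:
compound 1 `O=C(/C=C/c1cn(-c2ccccc2)nc1-c1cccnc1)c1ccsc1` gives 1700 nM in a functional assay on Huh-7 cells (Homo sapiens) for inhibition, read by sulforhodamine B assay, with a stated time of 72 h; a higher number here means a weaker inhibitor, a lower number a stronger inhibitor
compound 2 `COc1ccc(C(=O)/C=C/c2cn(-c3ccccc3)nc2-c2cccnc2)cc1OC` gives 3100 nM in this assay

Among the compounds with values here, compound 2 has the highest of the two numbers so far. Within the data shown here, its nearest neighbour is compound 1, and the step of a 1.8-fold higher number from compound 1 to compound 2 (0.26 log units; within the scatter) is the only measured step; it exchanges thiophen-3-yl for 3,4-dimethoxyphenyl on the carbonyl carbon and stays within the scatter, so the two compounds are not separated by this assay.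

Compound 3 `COc1ccc(OC)c(C(=O)/C=C/c2cn(-c3ccccc3)nc2-c2cccnc2)c1` has not been measured. It differs from compound 2 only in that the same atoms are joined differently: 2,5-dimethoxyphenyl in place of 3,4-dimethoxyphenyl on a carbonyl carbon. Among the measured compounds shown here, no measured step moves methoxy groups around a ring; the one step that touches this position, the thiophen-3-yl to 3,4-dimethoxyphenyl exchange, gave no change beyond the scatter. There is therefore nothing in the numbers that points to a step of any size in either direction in this assay.

For compound 3 the estimate is 3000 nM (range 1200 nM to 8000 nM), an expected step of a 1.0-fold lower number from compound 2 to compound 3 (0.01 log units; within the scatter), essentially no change from compound 2.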

Compound 3, half-maximal inhibitory concentration: 1300 nM
The estimate for compound 3 lay 2.3-fold (0.36 log units) above the measured number; the range from low to high includes it.
By their numbers in this assay, from the lowest: compounds 3, 1 and 2 (each within the scatter of the next, the first and the last beyond it).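

In this assay, moving the methoxy groups gives a 2.4-fold lower number from compound 2 to compound 3 (0.38 log units; beyond the scatter) and is the only step among these compounds that lies beyond the scatter, so 2,5-dimethoxyphenyl and 3,4-dimethoxyphenyl on the carbonyl carbon are separated even though the two groups have the same atoms and the same counts. This position therefore responds to how the methoxy groups are arranged on the ring, a dependence that the earlier exchange of thiophen-3-yl for 3,4-dimethoxyphenyl could not show. The exchange of thiophen-3-yl for 2,5-dimethoxyphenyl gives a 1.3-fold lower number from compound 1 to compound 3 (0.12 log units; within the scatter) and stays within the scatter, so a dimethoxyphenyl group as such does not set the reading, and no measurement here accounts for the effect of the arrangement.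

Still open, as far as these compounds go, is whether one methoxy group alone carries the step, or whether both are needed, and how a hydroxyl, an amine or a carboxylic acid on that ring would read. From the compounds shown here alone, all three compounds share the same core, so it is also open whether the difference between the two methoxy arrangements holds when the groups on that core are changed.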